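The source may report more compounds than this note shows. Statements on the series, on what has been measured and on what is new or still open speak of the compounds shown alone.

Of the compounds shown here, two sharing one core have been measured in an assay on HeLa cells for inhibition of sphingosine-1-phosphate transporter SPNS2 (Mus musculus), read by LC-MS, tested at 2 uM; a lower number here means less inhibition, a higher number more inhibition at the concentration tested (going by the name of the read-out). Compound 1 `CCCCCCCCCCc1ccc(-c2noc(C3CNC3)n2)cc1` gives 65%. Compound 2 `CCCCCCCCCCc1ccc(-c2noc([C@@H](N)CCCN)n2)cc1` gives 40%, the lower of the two numbers, after the change recorded as a number 25 percentage points lower from compound 1 to compound 2 (beyond the scatter). Compound 3 `CCCCCCCCCCc1ccc(-c2noc(CCCN3CCCCC3)n2)cc1` differs from compound 2 by 3-(piperidin-1-yl)propyl in place of 1,4-diaminobutyl on an aromatic carbon. For the measured compounds named here, no measured step swaps exactly these two groups; the single known step, a number 25 percentage points lower from compound 1 to compound 2 (beyond the scatter), concerns a different replacement at the same place and so offers only a loose guide. Compound 3 is therefore expected to fall near the middle of the measured numbers, at 50% (range 25% to 75%). The expected step is a number 10 percentage points higher from compound 2 to compound 3 (within the scatter).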

Compound 3, a percentage reported as inhibition, at one concentration (the size of the read-out at that concentration, not a potency): 0%
Beside the measured number, compound 3's estimate is 50 percentage points above it, and the stated range ends above it.
By their numbers in this assay, from the lowest: compound 3; then compound 2; then compound 1.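

In this assay, the group at this position can do more than reduce inhibition: 3-(piperidin-1-yl)propyl gives a number 40 percentage points lower from compound 2 to compound 3 (beyond the scatter), and against azetidin-3-yl it gives a number 65 percentage points lower from compound 1 to compound 3 (beyond the scatter). With this group, compound 3 reads 0%, so the choice of group here can decide whether any inhibition is seen at the concentration tested. No measured evidence accounts for this loss. As far as these compounds go, it remains open whether the piperidine ring or the change from 1,4-diaminobutyl as a whole matters most. A 3-aminopropyl group on the same carbon would help separate the chain from the ring.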